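Trimming the amide substituent of compound 3

A few compounds are considered here, and "the series" means these few. Any claim that something is new, unique, unknown or untested is made for them only; others in the source may bear on it.

Three compounds have values in an assay on HL-60 cells for agonist activity at vitamin D3 receptor (Homo sapiens), read by microscopy, with a stated time of 96 h; on this read-out lower numbers stand for an effect already at smaller amounts and higher numbers for an effect only at larger amounts of compound. Compound 1 `CCn1c(C(=O)N(C)CCC#N)ccc1C(CC)(CC)c1ccc(OCC(=O)C(C)(C)C)c(C)c1` gives 9800 nM, compound 2 `CCn1c(C(=O)N(CCC#N)CCC#N)ccc1C(CC)(CC)c1ccc(OCC(=O)C(C)(C)C)c(C)c1` gives 870 nM, and compound 3 `CC[C@@H](C)[C@H](NC(=O)c1ccc(C(CC)(CC)c2ccc(OCC(O)C(C)(C)C)c(C)c2)n1CC)C(=O)OC` gives 26 nM, the lowest of the three numbers. Among the compounds with values here, the one single-site step, an 11-fold lower number from compound 1 to compound 2 (1.05 log units; beyond the scatter), enlarges the group on the amide nitrogen. Compound 4 `CCn1c(C(=O)N(C)CC(=O)O)ccc1C(CC)(CC)c1ccc(OCC(O)C(C)(C)C)c(C)c1` goes the other way: (carboxymethyl)(methyl)amino in place of (1-(methoxycarbonyl)-2-methylbutyl)amino on a carbonyl carbon. That step shrinks the amide substituent, while compound 1 and compound 2 show that enlarging it lowered the number. A rise in the number is therefore expected, so for compound 4 the step of a 38-fold higher number from compound 3 to compound 4 (1.59 log units; beyond the scatter) is estimated. Compound 4 is expected to give about 1000 nM, within a range from 150 nM to 6000 nM.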

Compound 4, half-maximal effective concentration: 740 nM
Compound 4: the middle estimate sits 1.4-fold (0.13 log units) above what was measured, and the stated range covers the measured number.
By their numbers in this assay, from the lowest: compound 3; then compounds 4 and 2 (each within the scatter of the next); then compound 1.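

At this amide position, exchanging the whole substituent gives a 28-fold higher number from compound 3 to compound 4 (1.45 log units; beyond the scatter), so a shrinking of the group on the carbonyl carbon can cost as much as the enlargement between compounds 1 and 2 gained. The change is not a single one, though: the heavy-atom count falls, both defined stereocentres go, the methyl ester gives way to a carboxylic acid, and the nitrogen gains a methyl. Nothing available explains the rise. Which of these changes carries the step stays open. A methyl ester on the carboxymethyl group, or a longer chain in place of the N-methyl, would separate them.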